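Vero cytotoxicity of the amide series, next variant

This account rests on a few compounds, and the source may have more. Where it says the series, first, only, none or still open, it means among the compounds named here.

Measured so far in an ADME assay on Vero cells (Chlorocebus sabaeus) for cytotoxicity, read by resazurin assay, with a stated time of 3 days; on this read-out higher numbers stand for weaker inhibition and lower numbers for stronger inhibition:
compound 1 `CN(C)c1cc2[nH]c(C3CCCCC3)nc2cc1NC(=O)c1ccc(C(C)(C)C)cc1` gives > 100 ug/mL
compound 2 `CCc1ccc(C(=O)Nc2cc3nc(C4CCCCC4)[nH]c3cc2N(C)C)cc1` gives > 100 ug/mL

Both readings are limits of this assay and not numbers. For compound 1 the value > 100 ug/mL is a limit. For compound 2 the value > 100 ug/mL is likewise a limit. Within the data shown here, the one measured step, a step that the two limits leave unreadable from compound 1 to compound 2, therefore cannot be read, since the limit of > 100 ug/mL in this assay, at which 2 of the 2 values shown sit, covers both ends of it. Compound 2 thus stands at the limit of this assay, with no number to place it more closely.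

Compound 3 `CN(C)c1cc2[nH]c(C3CCCCC3)nc2cc1NC(=O)c1ccc(OC(F)(F)F)cc1` is not yet measured. It differs from compound 2 by trifluoromethoxy in place of ethyl on an aromatic carbon. No measured step in this assay bears on this change with a readable size; the only step shown, from compound 1 to compound 2, sits at the limit on both sides. There is therefore no basis to expect a step beyond the scatter in this assay in either direction, and the likeliest outcome is another limit reading. The expected step is a step that the limit leaves unreadable from compound 2 to compound 3. Compound 3 is estimated at 120 ug/mL, in the range 50 ug/mL to 300 ug/mL.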

Compound 3, half-maximal inhibitory concentration: > 100 ug/mL
Compound 3: only a limit was reported (the forecaster's own chance of this, stated with the estimate: 75%); the middle value does not contradict the limit.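

In this assay compound 3 gives > 100 ug/mL, which is a limit and not a number. Among these compounds, no step among compound 1, compound 2 and compound 3 can be read, since all three share one reading: the limit of > 100 ug/mL in this assay, at which 3 of the 3 values shown sit. The compounds shown leave open how far apart the tert-butyl, ethyl and trifluoromethoxy variants truly lie in this read-out.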